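Ortho-substituted aryl ureas: methoxy replacing tert-butyl

The compounds below may be only part of what the source reports. "The series", "measured", "known", "first", "only" and "open" are said of these compounds alone.

Measured compounds:
compound 1, `Cc1ccccc1NC(=O)N[C@H](C)c1ccccc1`, 99%
compound 2, `CC(C)c1ccccc1NC(=O)N[C@H](C)c1ccccc1`, 17%
compound 3, `C[C@@H](NC(=O)Nc1ccccc1C(C)(C)C)c1ccccc1`, 17%

In an ADME assay on the whole organism with Oryza sativa as the target, tested at 10 uM (on this read-out higher numbers stand for a weaker effect at the one concentration tested and lower numbers for a stronger effect), compound 3 stands level with compound 2 at the digits shown; the two are together the lowest of the three numbers, and compound 1 lies far higher. The steps show a number 82 percentage points lower from compound 1 to compound 2 (beyond the scatter) and a number 82 percentage points lower from compound 1 to compound 3 (beyond the scatter), both large, while no change at the digits printed from compound 2 to compound 3 (within the scatter).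

Compound 4, `COc1ccccc1NC(=O)N[C@H](C)c1ccccc1`, has not been measured. Its change from compound 3 is methoxy in place of tert-butyl on an aromatic carbon. Among the measured compounds shown here, no measured pair covers a methoxy group, so the only steps that bear on this change are those that exchange the group on the same aromatic carbon: a number 82 percentage points lower from compound 1 to compound 3 (beyond the scatter) and a number 82 percentage points lower from compound 1 to compound 2 (beyond the scatter). Going from tert-butyl to a much smaller group reverses the direction of the step from compound 1 to compound 3, so the number for compound 4 is expected to move upward, toward the level of compound 1, though a methoxy group is not a methyl group and the size of the return is uncertain. The step of a number 53 percentage points higher from compound 3 to compound 4 (beyond the scatter) is the expected change. Compound 4 is estimated at 70%, with a range from 25% to 100%.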

Compound 4, a percentage reported as activity, at one concentration (the size of the read-out at that concentration, not a potency): 96%
For compound 4 the middle estimate is 26 percentage points below the measured one; low and high end bracket the measured number.
By their numbers in this assay, from the lowest: compounds 2 and 3 (each within the scatter of the next); then compounds 4 and 1 (each within the scatter of the next).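

In this assay, methoxy in place of tert-butyl on this aromatic carbon, ortho to a large group, gives a number 79 percentage points higher from compound 3 to compound 4 (beyond the scatter), and methoxy in place of isopropyl gives a number 79 percentage points higher from compound 2 to compound 4 (beyond the scatter), so the low number seen with those two alkyl groups does not carry over to methoxy. Methoxy in place of methyl gives a number 3 percentage points lower from compound 1 to compound 4 (within the scatter), which places the two smaller substituents on one level and isopropyl and tert-butyl on another, a split that the earlier compounds could show only for alkyl groups and that now also holds for a group containing oxygen. No measurement is available that explains why the four groups divide in this way.

Four groups do not settle what separates the two levels: an ethyl group or an ethoxy group on the same carbon would test whether the split follows the count of heavy atoms or the branching of the alkyl groups. On these data alone, the rest of the core of compound 1 stays constant throughout, so it remains open whether the two levels persist when that part changes.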